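The source may hold more compounds than are shown below. What is called first, only, known or untested is meant among the compounds shown, and "the series" means these compounds.

Measured in a functional assay on HepG2 cells (Homo sapiens) for cytotoxicity, read by MTT assay, with a stated time of 24 h; on this read-out lower numbers stand for stronger inhibition and higher numbers for weaker inhibition:
- compound 1 `O=C1/C(=C/c2ccncc2)CN(S(=O)(=O)c2ccc(F)cc2)C/C1=C\c1ccccc1F`: 20300 nM
- compound 2 `O=C1/C(=C/c2ccncc2)CN(S(=O)(=O)c2ccc(Cl)cc2)C/C1=C\c1ccccc1F`: 5300 nM

Of these two, compound 2 has the lower number, at 5300 nM. Compound 3 `O=C1/C(=C/c2ccncc2)CN(S(=O)(=O)c2ccc(Cl)cc2)C/C1=C\c1ccccc1C(F)(F)F` keeps the chloro group of compound 2 and changes one substituent: trifluoromethyl in place of fluoro on an aromatic carbon. This places trifluoromethyl in place of fluoro on an aromatic carbon. Among the compounds with values here, the only measured step, a 3.8-fold lower number from compound 1 to compound 2 (0.58 log units; beyond the scatter), is modest and beyond the scatter, but it is a different exchange at another place, so it bears only indirectly. Within the data shown here, no step of clear direction can be drawn from it, and the expected change, a 1.2-fold lower number from compound 2 to compound 3 (0.07 log units; within the scatter), may stay within the scatter. Compound 3 is estimated at 4500 nM, with an expected range of 1500 nM to 14000 nM.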

Compound 3, half-maximal inhibitory concentration: 7190 nM
Compound 3: middle estimate off by 1.6-fold (0.20 log units), on the low side, and the stated range covers the measured number.
By their numbers in this assay, from the lowest: compounds 2 and 3 (each within the scatter of the next); then compound 1.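

At this position, on an aromatic carbon ortho to a large group, the exchange in this assay gives a 1.4-fold higher number from compound 2 to compound 3 (0.13 log units; within the scatter) and so shows that going from one heavy atom to four leaves the number within the scatter. Within the data shown here, the first reading at this place therefore shows no clear sensitivity to this change. No measurement at hand accounts for this result. From the compounds shown here alone, whether an amine or a carboxylic acid here would shift the number beyond the scatter remains open. So does whether this exchange would behave alike with the fluoro group of compound 1 in place of the chloro group.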